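A few compounds are considered here, and "the series" means these few. Any claim that something is new, unique, unknown or untested is made for them only; others in the source may bear on it.

The opening compound is compound 1 `CC(C)N(Cc1cccc(OCCCCCC(=O)O)c1)C(=O)c1ccccc1`, a benzamide whose aromatic ring carries no further substituent. In an ADME assay on HepG2 cells (Homo sapiens) for cytotoxicity, read by CellTiter-Glo and resazurin assay, with a stated time of 72 h (a lower number here means that less compound is needed, a higher number that more compound is needed for the effect), compound 1 gives > 26000 nM, which is a limit of the assay rather than a measured number. Compound 2 `CC(C)N(Cc1cccc(OCCCCCC(=O)O)c1)C(=O)c1ccc(-c2ccsc2)cc1` gives > 26000 nM in this assay, again a limit. Compound 3 `CC(C)N(Cc1cccc(OCCCCCC(=O)O)c1)C(=O)c1ccc(-c2ccc3[nH]ccc3c2)cc1` gives > 26000 nM, also a limit. The step that the two limits leave unreadable from compound 1 to compound 2, the step that the two limits leave unreadable from compound 1 to compound 3 and the step that the two limits leave unreadable from compound 2 to compound 3 therefore cannot be sized, since each pair sits on the same limit. Compound 1 thus stands alongside the other two on a shared limit with no number to place it above or below them.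

The new compound is compound 4 `CC(C)N(Cc1cccc(OCCCCCC(=O)O)c1)C(=O)c1ccc(-c2c[nH]c3ccccc23)cc1`. It differs from compound 1 in one place: 1H-indol-3-yl in place of hydrogen on an aromatic carbon. The measured steps that bear on it are those from compound 1 to compound 2 and to compound 3, where another aromatic group was added on the same carbon; neither gave a readable size. Because (the limit of > 26000 nM in this assay, at which 3 of the 3 values shown sit), no step beyond the scatter is expected for compound 4, and a value at or past the limit is the likely outcome. Compound 4 is therefore expected to give about 40000 nM, within a range of 18000 nM to 100000 nM, which means an estimated step that the limit leaves unreadable from compound 1 to compound 4.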

Compound 4, half-maximal effective concentration: > 26000 nM
Compound 4: no number, only a limit (the forecaster's own chance of this, stated with the estimate: 85%); the middle value is on the limit's open side.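

In this assay compound 4 gives > 26000 nM, which is a limit and not a number. Its steps from compound 1, compound 2 and compound 3 therefore cannot be read. The compounds shown leave open how far apart these four compounds truly lie, as none has a measured number.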